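Methoxy to sec-butoxy on the ester compound 3

The compounds below may be only part of what the source reports. "The series", "measured", "known", "first", "only" and "open" are said of these compounds alone.

In a functional assay on the whole organism (strain Sprague-Dawley) for inhibition, with Rattus norvegicus as the target, with a stated time of 10 min (on this read-out higher numbers stand for an effect only at larger amounts of compound and lower numbers for an effect already at smaller amounts), compound 3 `CCOC(=O)c1cnc(-c2ccccc2OC)[nH]c1=O` gives 10 mg/kg, level with compound 1 `COc1ccccc1-c1ncc(C(=O)O)c(=O)[nH]1` at 10 mg/kg. Together they hold the highest number of the three measured compounds. The propoxy acid, compound 2 `CCCOc1ccccc1-c1ncc(C(=O)O)c(=O)[nH]1`, gives 0.9 mg/kg.

Compound 4 `CCOC(=O)c1cnc(-c2ccccc2OC(C)CC)[nH]c1=O` keeps the ethyl ester of compound 3 and changes methoxy to sec-butoxy, on an oxygen on an aromatic ring: sec-butyl in place of methyl on an oxygen on an aromatic ring.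

For the measured compounds named here, two measured steps bear on this change. Going by the values given here, the only one that alters the group on this oxygen is an 11-fold lower number from compound 1 to compound 2 (1.05 log units; beyond the scatter), a large step measured on the acid and ending in propoxy. The ester step, no change at the digits printed from compound 1 to compound 3 (within the scatter), shows no cost of the ester when methoxy is present. Among the compounds with values here, the data hold no ester with a longer chain and no sec-butoxy compound, so carrying the large step over to the ester is an assumption. A step in the same direction and of similar size, though less certain, is therefore expected, and the expected step is an 8.3-fold lower number from compound 3 to compound 4 (0.92 log units; beyond the scatter). In this assay the estimate for compound 4 is 1.2 mg/kg, with an expected range of 0.35 mg/kg to 4.5 mg/kg.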

Compound 4, dose for 50% inhibition: 0.5 mg/kg
Beside the measured number, compound 4's estimate is 2.4-fold (0.38 log units) above it, within the range that was stated.
By their numbers in this assay, from the lowest: compounds 4 and 2 (each within the scatter of the next); then compounds 1 and 3 (each within the scatter of the next).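

In this assay, for the compounds shown here, the step of a 20-fold lower number from compound 3 to compound 4 (1.30 log units; beyond the scatter) shows that the group on the oxygen on the aromatic ring also governs the number on the ethyl ester, whereas the earlier compounds showed such a change only on the acid. Read alongside an 11-fold lower number from compound 1 to compound 2 (1.05 log units; beyond the scatter), it gives two large steps in the same direction, one ending in propoxy on the acid and one ending in sec-butoxy on the ester, so within these compounds the gain is tied neither to the free carboxylic acid nor to an unbranched chain. No available evidence accounts for either step.

From the compounds shown here alone, whether the sec-butyl shape itself matters or any longer chain on this oxygen would serve remains open, and a propoxy group on the ethyl ester and a sec-butoxy group on the carboxylic acid would be the pairs to separate these readings. Also open, going by these compounds, is how far the trend runs with a longer chain such as hexyl, or with an amine at the end of the chain.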